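A Ring Returns to an Ether Side Chain

The source may hold more compounds than are shown below. What is called first, only, known or untested is meant among the compounds shown, and "the series" means these compounds.

Of the compounds shown here, three sharing one core have been tested in an ADME assay on HEK293 cells (Homo sapiens) for cytotoxicity, with a stated time of 6 h; on this read-out lower numbers stand for higher toxicity in this test and higher numbers for lower toxicity in this test. Compound 1 `CCCCNc1nc(N)nc2cccc(CC3CCCC3)c12` gives > 25000 nM, which is a limit of the assay and not a number. Compound 2 `CCCCNc1nc(N)nc2cccc(CCc3ccccc3)c12` gives > 25000 nM, which is also only a limit. Within the data shown here, compound 3 `CCCCNc1nc(N)nc2cccc(OCCOC)c12` gives 10000 nM, the only true number among the three.

Compound 4 `CCCCNc1nc(N)nc2cccc(OCc3ccccc3OC)c12` differs from compound 3 in one place: 2-methoxyphenyl in place of methoxymethyl on a saturated chain carbon bound to an oxygen on an aromatic ring. In plain terms, 2-methoxyphenyl takes the place of methoxymethyl on a saturated chain carbon bound to an oxygen on an aromatic ring.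

Among the measured compounds shown here, two measured steps bear on this change. Both replace a ring-bearing group with 2-methoxyethoxy, giving an at least 2.5-fold lower number from compound 1 to compound 3 (0.39 log units; beyond the scatter) and an at least 2.5-fold lower number from compound 2 to compound 3 (0.39 log units; beyond the scatter). On these data alone, each starts from a limit, so its true size remains unknown. Compound 4 keeps the oxygen of compound 3 but brings back a ring, so it may recover part of those two steps. With only these two comparisons, that expectation is weak. The expected change is small and toward a higher number, namely a 1.5-fold higher number from compound 3 to compound 4 (0.18 log units; within the scatter). For compound 4, the estimated value in this assay is 15000 nM, with an expected range from 6000 nM to 30000 nM.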

Compound 4, half-maximal cytotoxic concentration: > 25000 nM
Compound 4: no number, only a limit; the forecaster's own chance of this, stated with the estimate: 35%; at least 1.6-fold (0.22 log units) between middle value and limit.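

Compound 4 gives > 25000 nM in this assay, which is a limit of the assay and not a number. The change in the side chain gives an at least 2.5-fold higher number from compound 3 to compound 4 (0.39 log units; beyond the scatter), so the oxygen on the aromatic ring does not by itself go with the lower number, and what is carried on the chain at this position matters in this small set. Compound 3 is now the only compound of the four with a true number, and the others cannot be ranked against one another: the limit of > 25000 nM in this assay, at which 3 of the 4 values shown sit.

The compounds shown leave open whether the six-membered aromatic ring itself matters or only the added atoms, a question that a longer saturated chain on the same oxygen could help to settle. On these data alone, it is also open whether a chain ending in an amine or a carboxylic acid would give a true number in this assay, and the full size of the step from the methoxymethyl to the 2-methoxyphenyl group stays unknown while one end of it is only a limit.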